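Side chain trimmed: compound 3 to compound 4

This account rests on a few compounds, and the source may have more. Where it says the series, first, only, none or still open, it means among the compounds named here.

In an in vitro ADME assay on microsomes from liver (Homo sapiens) for metabolic stability, tested at 5 uM (on this read-out higher numbers stand for a longer-lived compound and lower numbers for a shorter-lived compound), compound 1 `CCC(C)(C)Cn1nc(-c2cccs2)c(O)c(C2=NS(=O)(=O)c3cc(NS(C)(=O)=O)ccc3N2)c1=O` gives > 1 h as a limit and not a number. Compound 2 `CS(=O)(=O)Nc1ccc2c(c1)S(=O)(=O)N=C(c1c(O)c(-c3cccs3)nn(CCC3CC3)c1=O)N2` gives > 1 h which is also a limit. Compound 3 `COC(C)(C)CCn1nc(-c2cccs2)c(O)c(C2=NS(=O)(=O)c3cc(NS(C)(=O)=O)ccc3N2)c1=O` gives > 1 h which is likewise a limit. Compound 3 therefore stands only at the limit of > 1 h in this assay, at which 3 of the 3 values shown sit, and has no finer place in the series.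

Compound 4 `CCC(C)n1nc(-c2cccs2)c(O)c(C2=NS(=O)(=O)c3cc(NS(C)(=O)=O)ccc3N2)c1=O` follows with the change sec-butyl in place of 3-methoxy-3-methylbutyl on an aromatic nitrogen and carries sec-butyl in place of 3-methoxy-3-methylbutyl on an aromatic nitrogen.

Three measured steps in the same side chain bear on this change: a step that the two limits leave unreadable from compound 1 to compound 2 and a step that the two limits leave unreadable from compound 1 to compound 3 and also a step that the two limits leave unreadable from compound 2 to compound 3 in the series. None of them gives a size to carry over. No step beyond the scatter is therefore expected in this assay in either direction, and another limit is the likeliest report.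

For compound 4 the estimated value is 1.2 h with an expected range from 0.6 h to 2.5 h on this basis. The expected change is a step that the limit leaves unreadable from compound 3 to compound 4 in this estimate.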

Compound 4, half-life: > 1 h
Compound 4 gave a limit, no number (the forecaster's own chance of this, stated with the estimate: 75%); the middle value does not contradict the limit.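

In this assay compound 4 gives > 1 h, which is a limit and not a number. Within the data shown here, no step between compound 4 and compound 1, compound 2 or compound 3 can be read. The compounds shown leave open whether their side chains separate in half-life at all: the limit of > 1 h in this assay, at which 4 of the 4 values shown sit.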